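Phenyl placement and maximal response in the anilino-propanoic acid series

A few compounds are considered here, and "the series" means these few. Any claim that something is new, unique, unknown or untested is made for them only; others in the source may bear on it.

Within the data shown here, compound 1 `O=C(O)CCc1ccc(NCc2ccccc2)cc1` gives 89% in a functional assay on 1321-N1 cells for agonist activity at Free fatty acid receptor 1 (Homo sapiens), read by calcium flux (a lower number here means a smaller maximal response, a higher number a larger maximal response), the lowest of the three numbers measured so far; compound 3 `O=C(O)CCc1ccc(NCc2ccc(-c3ccccc3)cc2)cc1` gives 92% and compound 2 `O=C(O)CCc1ccc(NCc2ccc(Oc3ccccc3)cc2)cc1` gives 100%. Compound 4 `O=C(O)CCc1ccc(NCc2cccc(-c3ccccc3)c2)cc1` differs from compound 1 by phenyl in place of hydrogen on an aromatic carbon. The closest measured step is the same kind of substitution, a number 3 percentage points higher from compound 1 to compound 3 (within the scatter), which stayed within the scatter, while a number 11 percentage points higher from compound 1 to compound 2 (beyond the scatter) was modest. A small upward step at most, probably not beyond the scatter, is therefore expected for compound 4 in this assay. Compound 4 is estimated at 93%, with a range from 84% to 102%. The expected step is a number 4 percentage points higher from compound 1 to compound 4 (within the scatter).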

Compound 4, largest response reached (reported as efficacy), in percent of the reference or control that the assay uses: 101%
Compound 4: the middle estimate sits 8 percentage points below what was measured; measured number inside the range.
By their numbers in this assay, from the lowest: compounds 1, 3, 2 and 4 (each within the scatter of the next, the first and the last beyond it).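

In this assay, phenyl meta to a large group gives a number 12 percentage points higher from compound 1 to compound 4 (beyond the scatter), a modest rise, while the phenyl of compound 3 gave a number 3 percentage points higher from compound 1 to compound 3 (within the scatter). Only at this position does adding phenyl to compound 1 carry the response beyond the scatter, and no loss of maximal response appears. Nothing available explains this step.

Open, from the compounds shown here alone, is whether the rise needs a whole ring here or whether a methyl, methoxy or amine at this position would also give it. Phenoxy at this position also remains open.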